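This account rests on a few compounds, and the source may have more. Where it says the series, first, only, none or still open, it means among the compounds named here.

Of the compounds shown here, three built on one shared core have so far been tested in a functional assay on PC-12 cells (Rattus norvegicus) for cytotoxicity, read by MTT assay, with stated times of 2 h and 24 h, tested at 10 uM; a higher number here means a stronger effect of the compound at the concentration tested, a lower number a weaker effect. Compound 1 `CCc1ccc(-n2nc(-c3ccc(C(F)(F)F)cc3O)nc2-c2ccccc2O)cc1` gives 107% in this assay. Compound 2 `CC(C)c1ccc(-n2nc(-c3ccc(C(F)(F)F)cc3O)nc2-c2ccccc2O)cc1` gives 108% in this assay. Compound 3 `Oc1cc(C(F)(F)F)ccc1-c1nc(-c2ccccc2O)n(-c2ccccc2Cl)n1` gives 102% in this assay, the lowest of the three numbers, although both other numbers lie within the scatter of it: the nearest is compound 1, the furthest compound 2. Every step measured so far has been small. Along the saturated chain there was a number 1 percentage points higher from compound 1 to compound 2 (within the scatter). Exchanging the aryl group on the aromatic nitrogen gave a number 5 percentage points lower from compound 1 to compound 3 (within the scatter) and a number 6 percentage points lower from compound 2 to compound 3 (within the scatter).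

Compound 4 `COc1ccccc1-n1nc(-c2ccc(C(F)(F)F)cc2O)nc1-c1ccccc1O` is the next member of the series. It differs from compound 3 in a single place: methoxy in place of chloro on an aromatic carbon. The two steps that exchanged the aryl group on the aromatic nitrogen are the ones that bear on this change, and both stayed within the scatter, so no step beyond the scatter is expected in this assay in either direction. Compound 4 is therefore estimated to give about 103% in this assay, with a range from 91% to 115%. This estimate corresponds to an expected a number 1 percentage points higher from compound 3 to compound 4 (within the scatter).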

Compound 4, a percentage reported as activity, at one concentration (the size of the read-out at that concentration, not a potency): 96.2%
Compound 4: middle estimate off by 6.8 percentage points, on the high side; the range from low to high includes it.
By their numbers in this assay, from the lowest: compounds 4, 3, 1 and 2 (each within the scatter of the next, the first and the last beyond it).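

In this assay, methoxy in place of chloro, ortho to a large group, gave a number 5.8 percentage points lower from compound 3 to compound 4 (within the scatter), so this exchange on its own does not separate the two groups at this position. For the compounds shown here, the aryl group on the aromatic nitrogen, however, now shows the first steps beyond the scatter: 2-methoxyphenyl gave a number 11.8 percentage points lower from compound 2 to compound 4 (beyond the scatter) in place of 4-isopropylphenyl and a number 10.8 percentage points lower from compound 1 to compound 4 (beyond the scatter) in place of 4-ethylphenyl, whereas 2-chlorophenyl in the same two exchanges had stayed within the scatter, so the modest separation belongs to 2-methoxyphenyl alone and compound 3 sits unresolved between the two ends. No measurement at hand accounts for this small shift.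

The compounds shown leave open whether an amine or a carboxylic acid at this same ring carbon would carry the number further from those of compound 1 and compound 2 than methoxy does. They also leave open whether a longer chain on that oxygen, such as ethoxy, would extend the step or leave it within the scatter.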